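This account rests on a few compounds, and the source may have more. Where it says the series, first, only, none or still open, it means among the compounds named here.

This set of compounds was tested in a functional assay on HL-60 cells (Homo sapiens) for activation, read by flow cytometry, with a stated time of 4 days; on this read-out higher numbers stand for an effect only at larger amounts of compound and lower numbers for an effect already at smaller amounts. Compound 1 `COc1ccc(-n2cnc3cnc(-c4ccc(F)cc4C)cc32)cc1OC` gives 15 nM in this assay. Compound 2 `COc1ccc(-n2cnc3cnc(-c4ccc(F)cc4OC)cc32)cc1OC` gives 35 nM, and compound 3 `COc1ccc(-n2cnc3cnc(-c4ccc(F)cc4)cc32)cc1OC` gives 780 nM. These three share a core and differ only on one ring. The difference between compound 2 and compound 1 is methyl in place of methoxy on an aromatic carbon, and it made a step of a 2.3-fold higher number from compound 1 to compound 2 (0.37 log units; beyond the scatter). Going from compound 2 to compound 3 the difference is hydrogen in place of methoxy on an aromatic carbon, and this made a step of a 22-fold higher number from compound 2 to compound 3 (1.35 log units; beyond the scatter). Between compound 1 and compound 3 the step is a 52-fold higher number from compound 1 to compound 3 (1.72 log units; beyond the scatter), so compound 1 stands lowest of the three measured numbers.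

Compound 4 `COc1ccc(-n2cnc3cnc(-c4ccc(F)cc4C)cc32)cc1` has not yet been measured. It differs from compound 1 by hydrogen in place of methoxy on an aromatic carbon. Within the data shown here, this is the same kind of change as the one from compound 2 to compound 3, but it sits on a different ring: there the place was ortho to a large group and meta to a fluoro group, here it is ortho to a methoxy group and meta to a large group. The change from compound 2 to compound 3 made a large step, but nothing measured shows what removing a methoxy group from this other ring does. Among the measured compounds shown here, for compound 4 a smaller step than the one from compound 2 to compound 3 is expected, of about a 3.0-fold higher number from compound 1 to compound 4 (0.48 log units; beyond the scatter). Compound 4 is therefore estimated at 45 nM, expected to fall between 10 nM and 300 nM.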

Compound 4, half-maximal effective concentration: 6 nM
Estimate against measurement, compound 4: 7.5-fold (0.88 log units) above; the measured number lies below the stated range.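

Removing the methoxy group from the position ortho to a methoxy group and meta to a large group gave a 2.5-fold lower number from compound 1 to compound 4 (0.40 log units; beyond the scatter) in this assay, so here the change lowered the number and compound 4 needs a smaller amount for the effect than compound 1. The same exchange of a methoxy group for hydrogen therefore did not carry over from one case to the other, not even in direction: the two steps point opposite ways and their gap is wider than the usual scatter: the same change on two cores in this assay, a 22-fold higher number (1.35 log units; beyond the scatter) from compound 2 to compound 3 and a 2.5-fold lower number (0.40 log units; beyond the scatter) from compound 1 to compound 4, 56-fold (1.75 log units) apart, beyond the scatter of two such steps. This does not show why the two results differ or give a rule for the series. Each result rests on a single pair of compounds, and the two changes sit at different places. The data do not separate the place of the change from the surrounding structure.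

The compounds shown leave open what happens when the other methoxy group on that ring is replaced by hydrogen, or when both are. They also leave open whether a larger group at the position emptied in compound 4, such as an ethoxy group, an amine or a longer chain, would lower the number further or raise it again.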